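This account rests on a few compounds, and the source may have more. Where it says the series, first, only, none or still open, it means among the compounds named here.

Measured so far:
Compound 1, `COc1cccc(Nc2nc3nonc3nc2O)c1`: 75400 nM
Compound 2, `CCCCCCc1ccc(Nc2nc3nonc3nc2O)c(F)c1`: 3300 nM
Compound 3, `Cc1ccc(CNc2nc3nonc3nc2O)cc1`: 53200 nM

Of the compounds shown here, three sharing one core have been tested in an assay on mitochondria from L6 cells (Rattus norvegicus) for activation, with a stated time of 90 min; a higher number here means that more compound is needed for the effect, a lower number that less compound is needed. Among them compound 1 gives the highest number, meaning the most compound is needed. Its value and that of compound 3 lie within the usual scatter of each other, so no order between those two can be read. Compound 2, which carries a hexyl chain and a fluorine on its six-membered aromatic ring of carbon only, needs clearly less compound than compound 1, a gap well beyond the scatter.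

Compound 4, `Oc1nc2nonc2nc1Nc1cccc(C(F)(F)F)c1`, has not yet been measured. It differs from compound 1 in one place: trifluoromethyl in place of methoxy on an aromatic carbon.

For the measured compounds named here, with no measured pair showing a change of this kind, the size of the step is guesswork. The values of compounds 1 and 3 suggest that small groups on this ring leave the number high, while compound 2 shows that a different substitution can lower it a lot. A modest lowering is expected for compound 4, giving an estimated step of a 1.7-fold lower number from compound 1 to compound 4 (0.22 log units; within the scatter). Compound 4 is therefore estimated at 45000 nM, within a range from 12000 nM to 150000 nM.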

Compound 4, half-maximal effective concentration: 13300 nM
The estimate for compound 4 lay 3.4-fold (0.53 log units) above the measured number; the measured number falls inside the stated range.
By their numbers in this assay, from the lowest: compound 2; then compound 4; then compounds 3 and 1 (each within the scatter of the next).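

Replacing methoxy with trifluoromethyl on this aromatic carbon, meta to a large group, gives a 5.7-fold lower number from compound 1 to compound 4 (0.75 log units; beyond the scatter) in this assay. For the compounds shown here, this is the only step so far between compounds that differ in one place, and it shows that a change at this single position, with the shared core untouched, can move the number beyond the usual scatter. No measurement here explains the drop, and the change alters both the number of heavy atoms and the hydrogen-bond acceptor count, so its cause stays unknown.

With a single swap at this position, the compounds shown cannot tell whether the lower number comes from gaining trifluoromethyl or from losing methoxy. Also open, as far as these compounds go, is how a chlorine atom, an amine, a carboxylic acid or a longer chain would behave on this same carbon.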